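This account rests on a few compounds, and the source may have more. Where it says the series, first, only, none or still open, it means among the compounds named here.

For the measured compounds named here, in a functional assay on the whole organism (artery, strain albino) with Rattus norvegicus as the target, with a stated time of 360 min, at a dose of 10 mg/kg by the oral route (a lower number here means less inhibition, a higher number more inhibition at the dose given (going by the name of the read-out)), compound 2 `COc1ccc(C2N=C(SCc3ccc(Cl)cc3)NC(C)=C2C(=O)Nc2ccc(Br)cc2)cc1` gives 39.2%, the higher of the two numbers measured so far, while compound 1 `COc1ccc(C2N=C(SCc3ccccc3)NC(C)=C2C(=O)Nc2ccc(Br)cc2)cc1` gives 18.6%. Going by the values given here, the single measured step, a number 20.6 percentage points higher from compound 1 to compound 2 (beyond the scatter), is the only comparison on hand, and it sets chloro against hydrogen rather than against fluoro. Compound 3 `COc1ccc(C2N=C(SCc3ccc(F)cc3)NC(C)=C2C(=O)Nc2ccc(Br)cc2)cc1` differs from compound 2 by fluoro in place of chloro on an aromatic carbon. Compound 3 is expected to land between its two neighbours, with an estimated a number 11.2 percentage points lower from compound 2 to compound 3 (beyond the scatter). The expected value for compound 3 is therefore 28%, within a range from 10% to 46%.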

Compound 3, a percentage reported as inhibition, in the whole organism at one dose (the size of the read-out at that dose, not a potency): 33.5%
Compound 3: middle estimate off by 5.5 percentage points, on the low side, and the stated range covers the measured number.
By their numbers in this assay, from the lowest: compound 1; then compounds 3 and 2 (each within the scatter of the next).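

In this assay, the two halogens at this place on the ring cannot be told apart: fluoro in place of chloro gives a number 5.7 percentage points lower from compound 2 to compound 3 (within the scatter) and leaves the read-out within the usual scatter. Fluoro in place of hydrogen gives a number 14.9 percentage points higher from compound 1 to compound 3 (beyond the scatter), so the rise over compound 1 is no longer seen with chloro alone but also with fluoro. No measurement at hand offers an explanation for these numbers. The compounds shown leave open whether bromo, methoxy, a nitrile or an amine at this place would score like compound 2 and compound 3 or like compound 1. They also leave open whether the same halogens would behave alike elsewhere on the benzyl ring.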